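The source may hold more compounds than are shown below. What is called first, only, known or untested is meant among the compounds shown, and "the series" means these compounds.

The measured compounds:

compound 1, `O=C(c1cccnc1)N1CCC(NS(=O)(=O)c2cc(S(=O)(=O)c3ccccc3)ccc2C(F)(F)F)CC1`: 80 nM
compound 2, `O=C(c1ccc(Cl)nc1)N1CCC(NS(=O)(=O)c2cc(S(=O)(=O)c3ccccc3)ccc2C(F)(F)F)CC1`: 110 nM
compound 3, `O=C(O)CCCC(=O)N1CCC(NS(=O)(=O)c2cc(S(=O)(=O)c3ccccc3)ccc2C(F)(F)F)CC1`: 500 nM

All three numbers come from an assay on isolated protein for displacement of a labelled ligand from secreted frizzled-related protein 1 (Homo sapiens), read by fluorescence polarization, with a stated time of 30 min; on this read-out higher numbers stand for weaker inhibition and lower numbers for stronger inhibition. Compound 3 gives the highest of the three numbers: the step of a 4.5-fold higher number from compound 2 to compound 3 (0.66 log units; beyond the scatter) and the step of a 6.3-fold higher number from compound 1 to compound 3 (0.80 log units; beyond the scatter) both lie beyond the scatter, so compound 3 is the weakest of the measured set, while compound 1 and compound 2 sit within the scatter of each other, as the step of a 1.4-fold higher number from compound 1 to compound 2 (0.14 log units; within the scatter) shows.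

Compound 4, `O=C(C1CCNCC1)N1CCC(NS(=O)(=O)c2cc(S(=O)(=O)c3ccccc3)ccc2C(F)(F)F)CC1`, continues from compound 3 by one change: piperidin-4-yl in place of 3-carboxypropyl on a carbonyl carbon. The two measured steps that reach compound 3 both replace an aromatic ring on that carbonyl carbon with the 3-carboxypropyl chain and both raise the number modestly. The step to compound 4 removes that chain again, but what enters is a saturated ring with a nitrogen donor, not an aromatic ring, so neither measured step is a direct precedent; they only suggest that the open chain is the less favourable of the carbonyl substituents seen so far. On that basis a modest move back toward a lower number is expected for compound 4, and the step of a 2.0-fold lower number from compound 3 to compound 4 (0.30 log units; within the scatter) is the estimated size. Compound 4 is therefore estimated at 250 nM, within a range from 80 nM to 800 nM in this assay.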

Compound 4, half-maximal inhibitory concentration: 120 nM
For compound 4 the middle estimate is 2.1-fold (0.32 log units) above the measured one; the range from low to high includes it.
By their numbers in this assay, from the lowest: compounds 1, 2 and 4 (each within the scatter of the next); then compound 3.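

In this assay the change from an open chain to a saturated ring on this carbonyl carbon gives a 4.2-fold lower number from compound 3 to compound 4 (0.62 log units; beyond the scatter), which leaves compound 3 as the weakest of the four, with a step beyond the scatter to each of the others. The steps of a 1.5-fold higher number from compound 1 to compound 4 (0.18 log units; within the scatter) and a 1.1-fold higher number from compound 2 to compound 4 (0.04 log units; within the scatter) lie within the scatter, so among these compounds an aromatic ring is not needed here: piperidin-4-yl cannot be told apart from pyridin-3-yl or 6-chloropyridin-3-yl, and only 3-carboxypropyl stands apart. The groups exchanged between compound 3 and compound 4 have equal counts of heavy atoms, hydrogen-bond donors and hydrogen-bond acceptors, so those counts do not separate them, and nothing measured here gives a reason for the difference.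

The compounds shown do not separate the ring from its nitrogen, since a cyclohexyl group on this carbonyl carbon does not appear among them. Nor do they show whether the open chain or its carboxylic acid goes with the higher number, which a chain ending in an amine or a methyl ester would address.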